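The source may hold more compounds than are shown below. What is called first, only, known or untested is meant among the compounds shown, and "the series" means these compounds.

Measured so far:
- compound 1, `CC(C)(C)c1ccc(NC(=O)c2ccc(-c3ncccc3NC3CCCC3)cc2)cc1`, 44 nM
- compound 2, `CC(C)(C)c1ccc(NC(=O)c2ccc(-c3ncccc3C(=N)N)cc2)cc1`, > 4000 nM
- compound 3, `CN(C)Cc1cccnc1-c1ccc(C(=O)Nc2ccc(C(C)(C)C)cc2)cc1`, 234 nM

The series shares one amide core and varies only the group on the pyridine ring. In a functional assay for antagonist activity at transient receptor potential cation channel subfamily V member 1 (Rattus norvegicus) (a higher number here means a weaker inhibitor, a lower number a stronger inhibitor), compound 1 gives 44 nM. For compound 2 the result is a limit of the assay, > 4000 nM; the same limit is described under (the limit of > 4000 nM in this assay, at which 1 of the 3 values shown sits). Compound 3 gives 234 nM in this assay, the highest of the two numbers; its nearest neighbour is compound 1, a 5.3-fold higher number from compound 1 to compound 3 (0.73 log units; beyond the scatter).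

Compound 4, `CC(C)(C)c1ccc(NC(=O)c2ccc(-c3ncccc3-c3nnco3)cc2)cc1`, is not yet measured. It differs from compound 3 by 1,3,4-oxadiazol-2-yl in place of (dimethylamino)methyl on an aromatic carbon.

Among the measured compounds shown here, two steps bear on this change. Replacing cyclopentylamino by the small amidine gave an at least 90-fold higher number from compound 1 to compound 2 (1.95 log units; beyond the scatter), and from that amidine to the (dimethylamino)methyl of compound 3 the number moved back, an at least 17-fold lower number from compound 2 to compound 3 (1.23 log units; beyond the scatter). For the measured compounds named here, a small, acceptor-rich aromatic ring in this position has no direct precedent in the set; the loss seen with compound 2 and the intermediate standing of compound 3 suggest a moderate worsening is the more likely outcome.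

For compound 4 the expected step is a 3.0-fold higher number from compound 3 to compound 4 (0.48 log units; beyond the scatter), and the estimated value is 700 nM, with a plausible range from 150 nM to 3500 nM.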

Compound 4, half-maximal inhibitory concentration: 59 nM
The estimate for compound 4 lay 12-fold (1.07 log units) above the measured number; measured number outside the range, below it.
By their numbers in this assay, from the lowest: compounds 1 and 4 (each within the scatter of the next); then compound 3. At a limit, above all of these: compound 2.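

In this assay, the 1,3,4-oxadiazol-2-yl and cyclopentylamino groups cannot be told apart on this aromatic carbon: a 1.3-fold higher number from compound 1 to compound 4 (0.13 log units; within the scatter). Against the (dimethylamino)methyl group, the five-membered aromatic ring with 3 hetero atoms gives a clear gain, a 4.0-fold lower number from compound 3 to compound 4 (0.60 log units; beyond the scatter), which shows that neither an amine nor a non-aromatic ring is needed here for a number of this order. The amidine stands at a limit of the assay rather than at a number, so the step away from it, an at least 67-fold lower number from compound 2 to compound 4 (1.83 log units; beyond the scatter), gives only a minimum size, and the poor result of that group does not extend to every small group at this position.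

Whether this result is particular to the 1,3,4-oxadiazol-2-yl ring remains open, as the compounds shown include no phenyl, thiazole or 1,2,4-triazole at this place. From the compounds shown here alone, it is also open whether a carboxylic acid or a primary amide here would track the amidine or compound 4, and whether a longer chain on the amine of compound 3 would change its standing.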